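The source may hold more compounds than are shown below. What is called first, only, known or untested is meant among the compounds shown, and "the series" means these compounds.

Measured in an ADME assay on Vero cells (Chlorocebus sabaeus) for cytotoxicity, read by neutral red uptake, with a stated time of 72 h; on this read-out higher numbers stand for weaker inhibition and lower numbers for stronger inhibition:
compound 1, `Cc1ccc(Nc2ccnc(NCCCNc3ccnc4cc(Cl)ccc34)n2)cc1` — 18500 nM
compound 2, `COc1ccc(Nc2ccnc(NCCCNc3ccnc4cc(Cl)ccc34)n2)cc1` — 13300 nM
compound 3, `Cc1ccc(Nc2ccnc(NCCCCNc3ccnc4cc(Cl)ccc34)n2)cc1` — 19300 nM

Compound 1 and compound 2 differ by methoxy in place of methyl on an aromatic carbon, a change that gave a 1.4-fold lower number from compound 1 to compound 2 (0.14 log units; within the scatter). Compound 3 differs from compound 1 in its core; the difference between the two cores is not broken down here. Compound 4, `COc1ccc(Nc2ccnc(NCCCCNc3ccnc4cc(Cl)ccc34)n2)cc1`, stands to compound 3 as compound 2 stands to compound 1: the change is methoxy in place of methyl on an aromatic carbon, the same change at the same place description. In this assay compound 3 gives a number within the scatter of both compound 1 and compound 2, so the three measured numbers do not separate from one another. For the measured compounds named here, for compound 4 a step of about the same size as before is expected, a 1.4-fold lower number from compound 3 to compound 4 (0.14 log units; within the scatter), because a 1.4-fold lower number from compound 1 to compound 2 (0.14 log units; within the scatter) is the only precedent for this change. Compound 4 is therefore estimated at 14000 nM, with a likely range from 7000 nM to 28000 nM.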

Compound 4, half-maximal inhibitory concentration: 11100 nM
Compound 4: the middle estimate sits 1.3-fold (0.10 log units) above what was measured; the measured number falls inside the stated range.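

In this assay, methoxy in place of methyl on an aromatic carbon gives steps that do not separate on the two cores: the same change on two cores in this assay, a 1.4-fold lower number (0.14 log units; within the scatter) from compound 1 to compound 2 and a 1.7-fold lower number (0.24 log units; within the scatter) from compound 3 to compound 4, 1.3-fold (0.10 log units) apart, within the scatter of two such steps. The new step, a 1.7-fold lower number from compound 3 to compound 4 (0.24 log units; within the scatter), lies within the scatter, as does the earlier one, so the pair shows agreement across these two cores but not that the change itself moves the number. Two small steps on two closely related cores also do not show how the change would carry to a core further removed.

Still open, as far as these compounds go, is how an amine, a carboxylic acid or a halogen at the same place would read in this assay. A longer chain in the core also remains untested among the compounds shown.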